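The source may report more compounds than this note shows. Statements on the series, on what has been measured and on what is new or still open speak of the compounds shown alone.

Measured in a functional assay on the whole organism for positive allosteric modulation, with Mus musculus as the target; a lower number here means that less compound is needed, a higher number that more compound is needed for the effect:
- compound 1 `CCC(=O)N(c1cccc(C)c1)C1CCCC1N(C)C`: 25 mg/kg; 25 mg/kg (2 entries)
- compound 2 `CCC(=O)N(c1cccc(OC)c1)C1CCCC1N(C)C`: 4 mg/kg
- compound 3 `CCC(=O)N(c1cccc(Cl)c1)C1CCCC1N(C)C`: 20 mg/kg

These three compounds share one core and differ only in a single group on the aromatic ring. Compound 3 carries chloro and has the higher of the two single readings, while compound 1 has two matching readings instead of a single one. The closest single reading belongs to compound 2, and the step between them is a 5.0-fold higher number from compound 2 to compound 3 (0.70 log units; beyond the scatter). That step, with chloro in place of methoxy on an aromatic carbon, lies beyond the scatter and is modest in size.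

The next compound to consider is compound 4 `CCC(=O)N(c1cccc(Br)c1)C1CCCC1N(C)C`, which differs from compound 3 in one group: bromo in place of chloro on an aromatic carbon. For the measured compounds named here, no measured step here involves bromo, so the methoxy-to-chloro step shows only that a change at this place can register in this assay. It gives no direct size for this swap. One heavy atom replaces one heavy atom, and neither group adds a ring or a charge, so no step beyond the scatter is expected. The estimated change is a 1.1-fold lower number from compound 3 to compound 4 (0.05 log units; within the scatter). For compound 4 the expected value is 18 mg/kg, with an estimated range from 8 mg/kg to 40 mg/kg.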

Compound 4, dose for half-maximal effect: 2 mg/kg
Compound 4: middle estimate off by 9.0-fold (0.95 log units), on the high side, outside the stated range (below it).
By their numbers in this assay, from the lowest: compounds 4 and 2 (each within the scatter of the next); then compound 3.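

Putting bromo in place of chloro exchanges one heavy atom for one heavy atom, with no ring, hydrogen-bond donor, hydrogen-bond acceptor or net charge entering or leaving, yet it gives a 10-fold lower number from compound 3 to compound 4 (1.00 log units; beyond the scatter) in this assay and shows that this place on the aromatic ring can respond clearly even to so small a structural swap. The comparison with the methoxy compound gives a 2.0-fold lower number from compound 2 to compound 4 (0.30 log units; within the scatter) and so places these two very different groups level, while chloro stands apart from both, which means that a simple look at the group's size or type in this short series does not sort the numbers. Nothing available here explains why bromo and chloro differ so much in this whole-animal read-out.

Fluoro, iodo, trifluoromethyl or an amine at the same place would show whether bromo is an isolated case or part of a wider trend. The compounds shown also leave open whether bromo would give a similar result at another place on the ring, or with a longer chain in place of the propanoyl group of the shared core.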